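This account rests on a few compounds, and the source may have more. Where it says the series, first, only, none or still open, it means among the compounds named here.

Measured in a functional assay on LNCaP cells (Homo sapiens) for antiproliferative activity; a higher number here means a weaker inhibitor, a lower number a stronger inhibitor:
- compound 1 `Cn1ncc(Cl)c1-c1cc(C(=O)N[C@@H]2CN[C@H](CCNS(C)(=O)=O)C[C@H]2c2ccc(F)c(F)c2)oc1Cl`: 50 nM
- compound 2 `Cn1ncc(Cl)c1-c1cc(C(=O)N[C@@H]2CN[C@H](CC(N)=O)C[C@H]2c2ccc(Cl)c(Cl)c2)oc1Cl`: 160 nM
- compound 3 `CNC(=O)C[C@@H]1C[C@@H](c2ccc(F)c(F)c2)[C@H](NC(=O)c2cc(-c3c(Cl)cnn3C)c(Cl)o2)CN1`: 50 nM

Compound 2 stands highest of the three numbers; compound 1 and compound 3 both sit beyond the scatter from it, on the low side, and compound 1 and compound 3 lie within the scatter of each other. Among the compounds with values here, compound 2 is the only member of the set carrying the dichloro aryl; compound 1 and compound 3 carry the difluoro aryl, so no single-change step reaches compound 2 from either.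

Compound 4 `COCC[C@@H]1C[C@@H](c2ccc(Cl)c(Cl)c2)[C@H](NC(=O)c2cc(-c3c(Cl)cnn3C)c(Cl)o2)CN1` is not yet measured. It keeps the dichloro aryl of compound 2 and changes the chain: methoxymethyl in place of carbamoyl on a saturated chain carbon bound to a saturated ring carbon

Within the data shown here, the only measured step at the same place is no change at the digits printed from compound 1 to compound 3 (within the scatter), a swap of chain termini that left the number where it was. That step is the one that bears here, and it suggests the chain terminus is tolerant, though it covered different groups than the present pair. The expectation for compound 4 is therefore a step of no change at the digits printed from compound 2 to compound 4 (within the scatter), that is, no change beyond the scatter from compound 2. Compound 4 is expected to give 160 nM, with a range of 60 nM to 450 nM.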

Compound 4, half-maximal inhibitory concentration: 250 nM
The estimate for compound 4 lay 1.6-fold (0.19 log units) below the measured number, within the range that was stated.
By their numbers in this assay, from the lowest: compounds 1 and 3 (each within the scatter of the next); then compounds 2 and 4 (each within the scatter of the next).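

In this assay, within the data shown here, methoxymethyl in place of carbamoyl on a saturated chain carbon bound to a saturated ring carbon gives a 1.6-fold higher number from compound 2 to compound 4 (0.19 log units; within the scatter), so this step stays within the scatter on the dichloro aryl, whereas the earlier step at this place, no change at the digits printed from compound 1 to compound 3 (within the scatter), was seen only on the difluoro aryl. The step also removes the hydrogen-bond donor of carbamoyl, which shows that, on this chain and with this aryl, a terminus with no such donor stays within the scatter of one that has it. No measurement at hand explains this result.

As far as these compounds go, whether an amine, a carboxylic acid or a longer chain at this place would also stay within the scatter remains open. No pair shown differs at the aryl alone, so the effect of dichloro against difluoro cannot be separated from that of the chain.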